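From Oxetane to Oxolane: Expected Change in Clearance

This account rests on a few compounds, and the source may have more. Where it says the series, first, only, none or still open, it means among the compounds named here.

Compound 1 `NC(=O)[C@@H](CCC(F)(F)F)N(CC1COC1)S(=O)(=O)c1ccc(Cl)cc1`: 16.9 mL/min/kg
Compound 2 `CC1(C)CO[C@@H]1CN([C@H](CCC(F)(F)F)C(N)=O)S(=O)(=O)c1ccc(Cl)cc1`: > 293 mL/min/kg
Compound 3 `NC(=O)[C@@H](CCC(F)(F)F)N(C[C@@H]1CCCCO1)S(=O)(=O)c1ccc(Cl)cc1`: > 300 mL/min/kg

Within the data shown here, in an in vitro ADME assay on microsomes from liver (Homo sapiens) for metabolic stability, read by HPLC (on this read-out lower numbers stand for slow clearance and higher numbers for fast clearance), compound 1 gives 16.9 mL/min/kg, and that is the only actual number among the three measured compounds. Compound 2 reaches only the limit of > 293 mL/min/kg. Compound 3 likewise reaches only the limit of > 300 mL/min/kg. Compound 4 `NC(=O)[C@@H](CCC(F)(F)F)N(C[C@@H]1CCCO1)S(=O)(=O)c1ccc(Cl)cc1` has not yet been measured in this assay. It differs from compound 1 by oxolan-2-yl in place of oxetan-3-yl on a saturated chain carbon bound to a sulfonamide nitrogen. Among the measured compounds shown here, two measured steps bear on this change, both starting from the same oxetan-3-yl group of compound 1 and both ending in a limit: an at least 17-fold higher number from compound 1 to compound 2 (1.23 log units; beyond the scatter) and an at least 17-fold higher number from compound 1 to compound 3 (1.24 log units; beyond the scatter). The oxolan-2-yl group of compound 4 is a saturated oxygen ring of the same kind as those entering in compound 2 and compound 3, so a large move toward fast clearance is expected, a 12-fold higher number from compound 1 to compound 4 (1.07 log units; beyond the scatter). Compound 4 is therefore estimated to give about 200 mL/min/kg, between 60 mL/min/kg and 400 mL/min/kg, quite possibly again reported only as a limit.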

Compound 4, clearance: 210 mL/min/kg
Compound 4: the middle estimate sits 1.1-fold (0.02 log units) below what was measured, and the stated range covers the measured number.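

In this assay, the change from oxetan-3-yl to oxolan-2-yl on a saturated chain carbon bound to a sulfonamide nitrogen now has a real size rather than only a floor, with a 12-fold higher number from compound 1 to compound 4 (1.09 log units; beyond the scatter) as the first fully readable step away from oxetan-3-yl. Compound 2 and compound 3 are reported only as limits, not as numbers, so the comparisons with them are floors: an at least 1.4-fold lower number from compound 3 to compound 4 (0.15 log units; that floor lies within the scatter) and an at least 1.3-fold lower number from compound 2 to compound 4 (0.14 log units; that floor lies within the scatter) do not rank these rings. The step between compound 2 and compound 3 cannot be read.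

From the compounds shown here alone, it remains open whether the low number of compound 1 belongs to oxetan-3-yl alone or to other small rings as well. Oxolan-3-yl, or the amine ring azetidin-3-yl, at this place could help to tell these apart.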